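From a propanoyl to a methylcarbamoyl group in compound 4

The source may report more compounds than this note shows. Statements on the series, on what has been measured and on what is new or still open speak of the compounds shown alone.

Compound 1 `O=C1CCN(c2ccc(-c3ccccc3Cl)nn2)CC1` gives 35 mg/kg in a functional assay on the whole organism with Mus musculus as the target; on this read-out higher numbers stand for an effect only at larger amounts of compound and lower numbers for an effect already at smaller amounts
Compound 2 `O=C(OC1CCN(c2ccc(-c3ccccc3Cl)nn2)CC1)C1CC1` gives 92 mg/kg in this assay
Compound 3 `CCC(=O)OC1CCN(c2ccc(-c3ccc(Cl)cc3Cl)nn2)CC1` gives 16 mg/kg in this assay

Compound 3 has the lowest number of the three, and its gaps to compound 1 and to compound 2 both lie beyond the usual scatter. Compound 4 `CNC(=O)OC1CCN(c2ccc(-c3ccc(Cl)cc3Cl)nn2)CC1` carries methylamino in place of ethyl on a carbonyl carbon and otherwise matches compound 3. Within the data shown here, no measured pair shows this change on its own, so the data give no direct size for it. The step of a 1.3-fold higher number from compound 3 to compound 4 (0.10 log units; within the scatter) is expected to be small, with no shift in either direction beyond the scatter. The estimate for compound 4 is 20 mg/kg with an expected range from 8 mg/kg to 50 mg/kg on this read-out.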

Compound 4, dose for half-maximal effect: 1.4 mg/kg
The estimate for compound 4 lay 14-fold (1.15 log units) above the measured number, outside the stated range (below it).
By their numbers in this assay, from the lowest: compound 4; then compound 3; then compound 1; then compound 2.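

Methylamino in place of ethyl on a carbonyl carbon gives an 11-fold lower number from compound 3 to compound 4 (1.06 log units; beyond the scatter) in this assay, a large step. This place is thus highly sensitive to the group it carries, even though both groups count the same number of heavy atoms and only methylamino carries a hydrogen-bond donor. Nothing available explains the step. On these data alone, it remains open whether that donor hydrogen matters, which a dimethylamino group here would test, and whether an ethylamino group or a longer chain on the nitrogen would keep the low number.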